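Sulfonylpiperidine aromatase series: cyano to methylsulfonyl

The compounds below may be only part of what the source reports. "The series", "measured", "known", "first", "only" and "open" are said of these compounds alone.

Measured so far:
- compound 1 `N#Cc1ccc(S(=O)(=O)N2CCCC(Cn3ccnc3)C2)c(Cl)c1`: 79 nM
- compound 2 `N#Cc1ccc(S(=O)(=O)N2CCCC(Cn3ccnc3)C2)cc1`: 36 nM
- compound 3 `O=S(=O)(c1ccc(F)c(F)c1F)N1CCCC(Cn2ccnc2)C1`: 46 nM

In an assay on isolated protein for inhibition of Aromatase (Homo sapiens), read by fluorescence (on this read-out higher numbers stand for weaker inhibition and lower numbers for stronger inhibition), compound 2 gives 36 nM, the lowest number of the three, though the gap to compound 3 is within the scatter, so the two cannot be ordered. Among the measured compounds shown here, the only single-point step on record is a 2.2-fold lower number from compound 1 to compound 2 (0.34 log units; beyond the scatter), a modest gain on removing a substituent from the aryl ring.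

Compound 4 `CS(=O)(=O)c1ccc(S(=O)(=O)N2CCCC(Cn3ccnc3)C2)cc1` differs from compound 2 by methylsulfonyl in place of cyano on an aromatic carbon. For the measured compounds named here, no measured step touches this exchange at the para position: the change from compound 1 to compound 2 concerns a different group, and compound 3 carries a different substitution pattern altogether. The aryl variations seen so far move this assay by little, so a step of no more than the scatter is expected, with a slight lean toward a higher number. Compound 4 is therefore estimated at 55 nM, range 20 nM to 160 nM, corresponding to an expected step of a 1.5-fold higher number from compound 2 to compound 4 (0.18 log units; within the scatter).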

Compound 4, half-maximal inhibitory concentration: 48 nM
Beside the measured number, compound 4's estimate is 1.1-fold (0.06 log units) above it; the range from low to high includes it.
By their numbers in this assay, from the lowest: compounds 2, 3, 4 and 1 (each within the scatter of the next, the first and the last beyond it).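

Methylsulfonyl in place of cyano on this aromatic carbon, para to a large group, gives a 1.3-fold higher number from compound 2 to compound 4 (0.12 log units; within the scatter) in this assay, so this assay does not tell the two groups apart at this position. The nitrile of compound 2 is therefore not needed here to keep the number in this range, a point the earlier step, which concerned chloro and hydrogen at a different place, could not address. Nothing on hand offers an explanation for this result.

Still open, on these data alone, is how far this position accepts groups of another kind: an amine, a carboxylic acid or a longer alkyl chain could stay within the scatter or move beyond it. Also open, as far as these compounds go, is whether the same exchange stays this small with the chloro group of compound 1 present.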